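Isopropyl for phenyl on an amide-type nitrogen

This account rests on a few compounds, and the source may have more. Where it says the series, first, only, none or still open, it means among the compounds named here.

In a functional assay on HCT-116 cells (Homo sapiens) for cytotoxicity (on this read-out higher numbers stand for weaker inhibition and lower numbers for stronger inhibition), compound 1 (`CN1CCN(c2ccc(C(=O)Nc3n[nH]c4cc(C(=O)NC(C)(C)c5ccccc5)sc34)cc2)CC1`) gives 35 nM as its reading. Compound 2 (`CN1CCN(c2ccc(C(=O)Nc3n[nH]c4cc(C(=O)Nc5ccccc5)sc34)cc2)CC1`) is reported as "not active" (no number reported) and so has no single number. Compound 3 (`CC(C)NC(=O)c1cc2[nH]nc(NC(=O)c3ccc(N4CCN(C)CC4)cc3)c2s1`) differs from it by one change (isopropyl in place of phenyl on an amide-type nitrogen), isopropyl in place of phenyl on an amide-type nitrogen. Within the data shown here, no measured step gives the size of this change, so only a direction can be expected in this assay: stronger inhibition than compound 2, but probably weaker than compound 1 at 35 nM on this scale. Compound 3 is estimated at 400 nM with an expected range of 80 nM to 2500 nM on this read-out.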

Compound 3, half-maximal inhibitory concentration: 820 nM
Compound 3: the middle estimate sits 2.1-fold (0.31 log units) below what was measured, within the range that was stated.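

In this assay compound 3 gives 820 nM as a number, so isopropyl on the amide-type nitrogen keeps a measurable reading where the phenyl of compound 2 yields none, and that step cannot be read. Hydrogen in place of phenyl on the saturated chain carbon gives a 23-fold higher number from compound 1 to compound 3 (1.37 log units; beyond the scatter) and so shows that this phenyl counts for much in this assay on the present compounds. Still open, going by these compounds, is how a tert-butyl or benzyl group on this nitrogen would read. Nothing available explains these differences.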